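The compounds below may be only part of what the source reports. "The series", "measured", "known", "first", "only" and "open" are said of these compounds alone.

Measured compounds:
- compound 1, `CN(Cc1ccccc1Cl)C(=O)Nc1c(-c2ccc(F)cc2)c2ccccc2c(=O)n1C`: 480 nM
- compound 2, `Cc1cc2c(-c3ccccc3)c(NC(=O)N(C)Cc3ccccc3)n(C)c(=O)c2cc1C`: 16 nM
- compound 3, `COc1ccccc1CN(C)C(=O)c1c(-c2ccccc2)c2ccccc2c(=O)n1C`: 30 nM

All three were run in an assay on IM-9 cells for binding affinity to Substance-P receptor (Homo sapiens); on this read-out higher numbers stand for weaker inhibition and lower numbers for stronger inhibition. Compound 2 gives 16 nM, the lowest number of the three. The nearest number is that of compound 3, which gives 30 nM; the gap between these two lies within the scatter, so no order between compound 2 and compound 3 can be read from this assay. The furthest number is that of compound 1, which gives 480 nM; this gap lies beyond the scatter. Among the measured compounds shown here, no two of the measured compounds differ in a single place, so no step has been quantified.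

Compound 4, `Cc1cc(C)cc(CN(C)C(=O)Nc2c(-c3ccccc3)c3cc(C)c(C)cc3c(=O)n2C)c1`, has not yet been measured. It differs from compound 2 by one change: 3,5-dimethylphenyl in place of phenyl on a saturated chain carbon bound to an amide-type nitrogen. The shared core and the rest of the urea chain are unchanged. For the measured compounds named here, with no comparable step among the measured compounds, the expectation rests on compound 2 alone, whose value in this assay is 16 nM. The change is small and uncharged, and no shift beyond the scatter is expected in either direction. Compound 4 is therefore expected to give about 12 nM in this assay, estimated to fall between 4 nM and 40 nM. That estimate corresponds to an expected step of a 1.3-fold lower number from compound 2 to compound 4 (0.12 log units; within the scatter), which is expected to remain within the scatter.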

Compound 4, half-maximal inhibitory concentration: 28 nM
Estimate against measurement, compound 4: 2.3-fold (0.37 log units) below; the measured number falls inside the stated range.
By their numbers in this assay, from the lowest: compounds 2, 4 and 3 (each within the scatter of the next); then compound 1.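

In this assay, among the compounds shown here, 3,5-dimethylphenyl in place of phenyl on a saturated chain carbon bound to an amide-type nitrogen gives a 1.8-fold higher number from compound 2 to compound 4 (0.24 log units; within the scatter), the first step quantified at a single place. This position therefore carries either 3,5-dimethylphenyl or phenyl with no readable difference on this read-out, so benzyl and 3,5-dimethylbenzyl cannot be ordered here, and the urea chain tolerates this substitution on its aromatic ring without a shift beyond the scatter. Nothing available bears on the reason for this outcome.

Open, from the compounds shown here alone, is whether a group that is not a carbon-only aromatic ring at this place, such as a pyridine ring, or a benzyl bearing an amine or a carboxylic acid, would move the number beyond the scatter, since only phenyl and 3,5-dimethylphenyl are compared here. Compound 1 and compound 3 each differ from compound 2 in more than one place, so the steps that would link them to the rest of the series cannot be read.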